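The source may hold more compounds than are shown below. What is called first, only, known or untested is meant among the compounds shown, and "the series" means these compounds.

Compound 1 `CC1=C(C(=O)Nc2ccc(Br)cc2)C(c2ccc(Cl)cc2Cl)N=C(SCc2ccccc2)N1` and compound 2 `CC1=C(C(=O)Nc2ccc(Br)cc2)C(c2ccc(Cl)cc2Cl)N=C(SCc2cccc(Cl)c2)N1` share one core and differ only where a chloro replaces a hydrogen on an aromatic carbon. In a functional assay on the whole organism (artery, strain albino) with Rattus norvegicus as the target, with a stated time of 180 min, at a dose of 10 mg/kg by the oral route (on this read-out lower numbers stand for less inhibition and higher numbers for more inhibition at the one dose given (going by the name of the read-out)), compound 1 gives 13.4%, and compound 2 gives 11.9%. Among the compounds with values here, the one step that joins them, a number 1.5 percentage points lower from compound 1 to compound 2 (within the scatter), stays within the scatter, so the two numbers cannot be ordered against each other. Compound 3 `CC1=C(C(=O)Nc2ccc(Br)cc2)C(c2ccc(Cl)cc2Cl)N=C(SCc2ccc(Cl)cc2)N1` now has the chlorine in a different place on the same ring: 4-chlorophenyl in place of 3-chlorophenyl on a saturated chain carbon bound to a sulfur. That earlier step is the only one that bears on this change, and it showed nothing beyond the scatter, so compound 3 is expected to stay close to compound 2, with the expected step of a number 0.6 percentage points higher from compound 2 to compound 3 (within the scatter) being nothing beyond the scatter. The estimate for compound 3 in this assay is therefore 12.5%, with a range from 3% to 22%.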

Compound 3, a percentage reported as inhibition, in the whole organism at one dose (the size of the read-out at that dose, not a potency): 23.2%
Estimate against measurement, compound 3: 10.7 percentage points below; the measured number lies above the stated range.
By their numbers in this assay, from the lowest: compounds 2, 1 and 3 (each within the scatter of the next, the first and the last beyond it).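

Moving the chlorine on the ring gives a number 11.3 percentage points higher from compound 2 to compound 3 (beyond the scatter) in this assay, so on this saturated chain carbon bound to a sulfur, 4-chlorophenyl and 3-chlorophenyl can be told apart, which the earlier pair of compounds gave no sign of. Set against the unsubstituted ring, the same 4-chlorophenyl gives a number 9.8 percentage points higher from compound 1 to compound 3 (within the scatter) and so cannot be ordered against it; only the two chlorinated compounds stand apart, and the effect of the chlorine's place is not a clear effect of adding chlorine. Nothing measured here offers an explanation for this difference between the two chlorine placements.

From the compounds shown here alone, it remains open whether a methoxy group or a fluorine in place of the chlorine of the 4-chlorophenyl would follow the same course. A longer chain between the sulfur and the ring also remains an open question.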